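Amino for chloro on the shared core: next step

A few compounds are considered here, and "the series" means these few. Any claim that something is new, unique, unknown or untested is made for them only; others in the source may bear on it.

Measured so far in a functional assay on SK-MEL-28 cells (Homo sapiens) for cytotoxicity, read by sulforhodamine B assay, with a stated time of 48 h; on this read-out lower numbers stand for higher toxicity in this test and higher numbers for lower toxicity in this test:
compound 1 `ClCc1cccc(Cn2cnc3c(Cl)ncnc32)c1` gives 28800 nM.
Compound 2 `ClCc1cccc(Cn2cnc3c(Cl)nc(Cl)nc32)c1` gives only a limit, > 100000 nM.

Compound 2 therefore stands at the limit of this assay, described by the limit of > 100000 nM in this assay, at which 1 of the 2 values shown sits; the step of an at least 3.4-fold higher number from compound 1 to compound 2 (0.54 log units; beyond the scatter) is the only measured one.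

Compound 3 `Nc1nc(Cl)c2ncn(Cc3cccc(CCl)c3)c2n1` differs from compound 2 by amino in place of chloro on an aromatic carbon. For the measured compounds named here, no measured step exchanges chloro for amino, so the direction rests on compound 2 being a limit only, and the chloro-for-hydrogen step an at least 3.4-fold higher number from compound 1 to compound 2 (0.54 log units; beyond the scatter) does not bear directly on it. Compound 3 is estimated at 50000 nM, range 12000 nM to 200000 nM, which would mean an expected step of an at least 2.0-fold lower number from compound 2 to compound 3 (0.30 log units; that floor lies within the scatter).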

Compound 3, concentration lethal to 50% of the cells: 74100 nM
For compound 3 the middle estimate is 1.5-fold (0.17 log units) below the measured one; measured number inside the range.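

In this assay, amino in place of hydrogen at this position gives a 2.6-fold higher number from compound 1 to compound 3 (0.41 log units; beyond the scatter), so a higher number here does not depend on chloro. For compound 2, > 100000 nM is a limit. Amino in place of chloro gives an at least 1.3-fold lower number from compound 2 to compound 3 (0.13 log units; that floor lies within the scatter), so the two groups cannot be ordered at this position, although amino gives a readable value.

On these data alone, whether a methoxy or dimethylamino group at this position would follow amino remains open. So does whether the amino step holds when the chloromethyl group changes.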